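The compounds below may be only part of what the source reports. "The series", "measured", "known", "first", "only" and "open" are said of these compounds alone.

In a functional assay on MDA-MB-231 cells (Homo sapiens) for inhibition, read by sulforhodamine B assay, with a stated time of 72 h (on this read-out lower numbers stand for stronger inhibition of growth and higher numbers for weaker inhibition of growth), compound 1 `CNC(=O)/C=C/c1ccncc1-c1ccc2ccccc2c1` gives 8680 nM and compound 3 `CCOC(=O)/C=C/c1ccncc1-c1ccc2ccccc2c1` gives 8090 nM. These two values lie within the scatter of each other.

Compound 2 `NNC(=O)CCc1ccncc1-c1ccc2ccccc2c1` gives only a limit, > 10000 nM, and this is the limit of > 10000 nM in this assay, at which 1 of the 3 values shown sits.

Compound 4 `O=C(CCc1ccncc1-c1ccc2ccccc2c1)N1CCOCC1` carries morpholin-4-yl in place of aminoamino on a carbonyl carbon. For the measured compounds named here, no measured step makes this exchange. The closest evidence is the other change on a carbonyl carbon, a 1.1-fold lower number from compound 1 to compound 3 (0.03 log units; within the scatter), which lies within the scatter. The two steps that involve compound 2 are an at least 1.1-fold higher number from compound 1 to compound 2 (0.06 log units; that floor lies within the scatter) and an at least 1.2-fold lower number from compound 2 to compound 3 (0.09 log units; that floor lies within the scatter), and their floors also lie within the scatter.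

On this evidence, no step beyond the scatter is expected in this assay, and no direction can be favoured. The expected change is a step that the limit leaves unreadable from compound 2 to compound 4. Compound 4 is estimated at 11000 nM, with an expected range from 5500 nM to 22000 nM.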

Compound 4, concentration for 50% growth inhibition: > 10000 nM
Compound 4 ended at the assay's limit; the forecaster's own chance of this, stated with the estimate: 60%; the middle value is on the limit's open side.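

For the compounds shown here, compound 2 and compound 4 both end at a limit rather than a number, so no step between them can be read: the limit of > 10000 nM in this assay, at which 2 of the 4 values shown sit. The compounds shown leave open whether morpholin-4-yl in place of aminoamino on a carbonyl carbon changes growth inhibition at all.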